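The source may report more compounds than this note shows. Statements on the series, on what has been measured and on what is new or still open speak of the compounds shown alone.

The measured compounds are compound 1 `O=S(=O)(c1ccc(Cl)c(Cl)c1)c1ccc(O)nn1`, compound 2 `O=S(=O)(c1ccc(O)nn1)c1cc2ccccc2[nH]1` and compound 3 `O=c1ccc(S(=O)(=O)c2cc3cc(Cl)ccc3o2)n[nH]1`. In a functional assay on the whole organism for inhibition, with Rattus norvegicus as the target, with a stated time of 60 min, at pH 4.5, at a dose of 10 mg/kg by the oral route (a higher number here means a stronger effect of the compound at the dose given, a lower number a weaker effect), compound 1 gives 60%, compound 2 gives 58% and compound 3 gives 39%.

Compound 3 stands lowest of the three. Its nearest neighbour is compound 2, whose number lies higher by a margin beyond the scatter, and compound 1 lies higher still, again beyond the scatter. Compound 3 is thus the weakest of the three on the numbers shown.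

Compound 4 `O=c1ccc(S(=O)(=O)c2cc3cc(Cl)cc(Cl)c3o2)n[nH]1` has not yet been measured in this assay. Relative to compound 3 the change is chloro in place of hydrogen on an aromatic carbon. Among the measured compounds shown here, no step between two measured compounds tells what this particular change does, so the expectation rests on compound 3 alone. Compound 4 is expected to come out close to compound 3, with a step of a number 3 percentage points higher from compound 3 to compound 4 (within the scatter) that stays within the scatter. The estimate for compound 4 in this assay is 42%, with a range from 22% to 62%.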

Compound 4, a percentage reported as inhibition, in the whole organism at one dose (the size of the read-out at that dose, not a potency): 39%
Beside the measured number, compound 4's estimate is 3 percentage points above it; low and high end bracket the measured number.
By their numbers in this assay, from the lowest: compounds 3 and 4 (each within the scatter of the next); then compounds 2 and 1 (each within the scatter of the next).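

In this assay, chloro in place of hydrogen on an aromatic carbon, ortho to a fused ring and meta to the chloro group of the shared core, gives no change at the digits printed from compound 3 to compound 4 (within the scatter). Among the compounds shown here, this is the first step that can be read at this position, and it shows that the position takes this added chloro group with no difference beyond the scatter at the single oral dose tested. Nothing available offers an explanation for this outcome.

As far as these compounds go, whether a different group at this position, such as an amine, a methoxy group or a carboxylic acid, would leave the read-out equally unmoved remains open. Also open, from the compounds shown here alone, is whether the same result would hold at other doses, as one dose gives the size of the effect and not a potency.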